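The compounds below may be only part of what the source reports. "The series", "measured", "known", "first", "only" and "open" are said of these compounds alone.

Measured so far:
- `CC(C)(C)Cc1c(-c2cc(F)ccc2F)sc(N)c1C(=O)c1ccc(Cl)cc1`: in an assay on CHO cells for displacement of a labelled ligand from adenosine receptor A3 (Homo sapiens), read by scintillation counting, tested at 10 uM (on this read-out lower numbers stand for less inhibition and higher numbers for more inhibition at the one concentration tested (going by the name of the read-out)), compound 1 gives 1%
- `COc1ccc(-c2sc(N)c(C(=O)c3cccc(Cl)c3)c2CC(C)(C)C)cc1`: in this assay compound 2 gives 2%

Compound 1 stands lowest of the two numbers shown, with compound 2 close beside it; the two values lie within the usual scatter of each other, so neither can be called different from the other. Both show almost no displacement of the labelled ligand at the single concentration tested.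

The next compound, compound 3 `CC(C)(C)Cc1c(-c2cccs2)sc(N)c1C(=O)c1ccc(Cl)cc1`, has not been measured in this assay. It differs from compound 1 in one place: thiophen-2-yl in place of 2,5-difluorophenyl on an aromatic carbon. Among the measured compounds shown here, no pair of measured compounds in this set shows how such a change shifts the read-out, so the only guide is that two neighbours of compound 3 sit near the floor. Compound 3 is expected to stay near that floor, with a step of a number 4 percentage points higher from compound 1 to compound 3 (within the scatter) of no size beyond the scatter. The estimate for compound 3 is 5%, within a range from 0% to 20%.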

Compound 3, a percentage reported as inhibition, at one concentration (the size of the read-out at that concentration, not a potency): 1%
Compound 3: the middle estimate sits 4 percentage points above what was measured; the measured number falls inside the stated range.
By their numbers in this assay, from the lowest: compounds 1, 3 and 2 (each within the scatter of the next).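

Placing thiophen-2-yl where compound 1 carries 2,5-difluorophenyl, on the aromatic carbon next to the ring sulfur, gives the first one-place comparison in this set, and in this assay it shows no change at the digits printed from compound 1 to compound 3 (within the scatter) for this change. At this position, then, a five-membered aromatic ring with one sulfur does no more than the six-membered carbon ring it replaces to bring out displacement of the labelled ligand, although with both compounds so close to the bottom of the scale, this step cannot reveal any finer difference between the two rings. Nothing available offers a reason for this result.

From the compounds shown here alone, whether an amine or a carboxylic acid at this position would raise the number remains open. So does whether a longer chain in place of the neopentyl group would.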